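Pyrimidinyl in place of the carboxypyridinyl group

A few compounds are considered here, and "the series" means these few. Any claim that something is new, unique, unknown or untested is made for them only; others in the source may bear on it.

In an assay (Rattus norvegicus) for inhibition of Fatty-acid amide hydrolase 1 (Homo sapiens) (on this read-out lower numbers stand for stronger inhibition and higher numbers for weaker inhibition), compound 1 `O=C(CCCCCCc1ccccc1)c1ncc(-c2ccc(O)cc2)o1` gives 140 nM. Compound 2 `NC(=O)c1ccc(-c2cnc(C(=O)CCCCCCc3ccccc3)o2)cc1` gives 10 nM in this assay, a 14-fold lower number from compound 1 to compound 2 (1.15 log units; beyond the scatter). Compound 3 `O=C(CCCCCCc1ccccc1)c1ncc(-c2ncccc2C(=O)O)o1` reaches only > 50 nM in this assay, which is a limit and not a number (the limit of > 50 nM in this assay, at which 1 of the 3 values shown sits). Compound 4 `O=C(CCCCCCc1ccccc1)c1ncc(-c2ncccn2)o1` differs from compound 3 by pyrimidin-2-yl in place of 3-carboxypyridin-2-yl on an aromatic carbon. The steps onto compound 3 are a step that the limit leaves unreadable from compound 1 to compound 3 and an at least 5.0-fold higher number from compound 2 to compound 3 (0.69 log units; beyond the scatter); only the second is readable, and it marks the carboxypyridinyl compound as weaker than the carbamoyl compound. Removing the carboxy group is therefore expected to move back toward the measured range, an expected step that the limit leaves unreadable from compound 3 to compound 4, though the size is uncertain since the whole ring changes. Compound 4 is estimated at 100 nM, within 25 nM to 500 nM.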

Compound 4, inhibition constant: 5.3 nM
Beside the measured number, compound 4's estimate is 19-fold (1.28 log units) above it, and the stated range ends above it.
By their numbers in this assay, from the lowest: compounds 4 and 2 (each within the scatter of the next); then compound 1.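

Pyrimidin-2-yl, with 0 hydrogen-bond donors and no further substituent, is enough at this position in this assay: it gives a 26-fold lower number from compound 1 to compound 4 (1.42 log units; beyond the scatter) and a 1.9-fold lower number from compound 2 to compound 4 (0.28 log units; within the scatter). The change from the carboxypyridinyl group gives an at least 9.4-fold lower number from compound 3 to compound 4 (0.97 log units; beyond the scatter). The value of compound 3 is only a limit: the limit of > 50 nM in this assay, at which 1 of the 4 values shown sits.

This change removes the carboxy group and alters the ring at once, so the shown step does not separate the two. From the compounds shown here alone, whether a plain pyridin-2-yl group, or an amine on the pyrimidine ring, would hold this level remains open.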